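Swapping the dichlorophenyl acyl group of compound 1

The compounds below may be only part of what the source reports. "The series", "measured", "known", "first", "only" and "open" are said of these compounds alone.

Compound 1, `CN(C(=O)NC(=O)c1ccc(Cl)cc1Cl)c1nc(C(F)(F)F)c(C(=O)N/N=C/c2cccc(C(F)(F)F)c2)s1`, gives 11.2 ug/mL in a functional assay on HepG2 cells (Homo sapiens) for inhibition, read by MTT assay, with a stated time of 72 h (on this read-out higher numbers stand for weaker inhibition and lower numbers for stronger inhibition), the lowest of the two numbers reported, with compound 3, `COc1ccc(/C=N/NC(=O)c2sc(N(C)C(=O)NC(=O)c3c(F)cccc3F)nc2C)cc1`, giving the nearest number at 22.7 ug/mL. Compound 2, `CN(C(=O)NC(=O)c1ccc(Cl)cc1Cl)c1nc(C(F)(F)F)c(C(=O)N/N=C/c2cc(C(F)(F)F)cc(C(F)(F)F)c2)s1`, reaches only the limit of the assay at > 100 ug/mL. Among the measured compounds shown here, the only measured step, an at least 8.9-fold higher number from compound 1 to compound 2 (0.95 log units; beyond the scatter), sits on the hydrazone side of the shared core, where the limit of > 100 ug/mL in this assay, at which 1 of the 3 values shown sits, caps what can be read from it. Compound 4, `CN(C(=O)NC(=O)c1ccc(F)c(F)c1)c1nc(C(F)(F)F)c(C(=O)N/N=C/c2cccc(C(F)(F)F)c2)s1`, differs from compound 1 at the other end: 3,4-difluorophenyl in place of 2,4-dichlorophenyl on a carbonyl carbon. For the measured compounds named here, no measured pair isolates this change, since compound 3 differs from compound 1 in several places at once. Going by the values given here, with no step bearing on the acyl aryl group, the expectation for compound 4 is a number close to that of compound 1, with a step of a 1.3-fold higher number from compound 1 to compound 4 (0.13 log units; within the scatter) that is not expected to exceed the scatter. Compound 4 is therefore estimated at 15 ug/mL, with a range from 6 ug/mL to 45 ug/mL.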

Compound 4, half-maximal inhibitory concentration: 5.6 ug/mL
For compound 4 the middle estimate is 2.7-fold (0.43 log units) above the measured one; measured number outside the range, below it.
By their numbers in this assay, from the lowest: compounds 4 and 1 (each within the scatter of the next); then compound 3. At a limit, above all of these: compound 2.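

In this assay, among the compounds shown here, 3,4-difluorophenyl in place of 2,4-dichlorophenyl on a carbonyl carbon gives a 2.0-fold lower number from compound 1 to compound 4 (0.30 log units; within the scatter) and so provides the first single-change comparison at this end of the molecule. This exchange of one dihalogenated phenyl group for another therefore leaves a difference that cannot be told from the usual scatter, whereas the step on the hydrazone side, an at least 8.9-fold higher number from compound 1 to compound 2 (0.95 log units; beyond the scatter), ends at a limit of the assay. Nothing measured here accounts for the result at the acyl aryl group.

The compounds shown do not separate the kind of halogen from its place on the ring, as both change together in this pair. They also leave open how this end would respond to an amine or a carboxylic acid on the phenyl ring, or to a longer alkyl chain in place of the ring.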